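Moving the Chlorine Around the Ring on the Core Nitrogen

The source may hold more compounds than are shown below. What is called first, only, known or untested is meant among the compounds shown, and "the series" means these compounds.

Of the compounds shown here, three of one shared core have been measured so far in an ADME assay on V79 cells (Cricetulus griseus) for cytotoxicity, read by MTT assay, with a stated time of 72 h; a higher number here means a weaker inhibitor, a lower number a stronger inhibitor. Compound 1 `COc1ccc(Nc2nnnn2-c2ccc(Br)cc2)cc1` gives 125000 nM, compound 3 `COc1ccc(Nc2nnnn2-c2ccc(F)cc2)cc1` gives 145000 nM, and compound 2 `COc1ccc(-n2nnnc2Nc2ccccc2Cl)cc1` gives 246000 nM. Compound 2 holds the top figure of the three, yet its gaps to compound 3 and to compound 1 both lie within the scatter, so the three numbers are not distinguished by this assay. For the measured compounds named here, the one step between measured neighbours is a 1.2-fold higher number from compound 1 to compound 3 (0.06 log units; within the scatter), a change on the ring attached to the core on the other side.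

Compound 4 `COc1ccc(-n2nnnc2Nc2ccc(Cl)cc2)cc1` is the next compound to be measured. It differs from compound 2 as follows: 4-chlorophenyl in place of 2-chlorophenyl on a nitrogen on an aromatic ring. Going by the values given here, no measured step touches this position; the only step available concerns a different ring and is itself within the scatter. The expectation for compound 4 therefore rests on compound 2 alone, with its value of 246000 nM, and is that a 1.1-fold lower number from compound 2 to compound 4 (0.03 log units; within the scatter) should stay within the scatter. Compound 4 is thus expected to give about 230000 nM in this assay, within a range from 110000 nM to 480000 nM.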

Compound 4, half-maximal inhibitory concentration: 245000 nM
Compound 4: middle estimate off by 1.1-fold (0.03 log units), on the low side; the range from low to high includes it.
By their numbers in this assay, from the lowest: compounds 1, 3, 4 and 2 (each within the scatter of the next).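

In this assay, for the compounds shown here, 4-chlorophenyl in place of 2-chlorophenyl on a nitrogen on an aromatic ring gives a 1.0-fold lower number from compound 2 to compound 4 (0.00 log units; within the scatter), the first measured step at this position. The two groups carry the same heavy atoms, and this read-out does not tell them apart, so where the chlorine stands on this ring leaves no mark that the assay can detect between the two compounds, something the earlier step from bromo to fluoro on a different ring could not show. Nothing measured here offers an explanation for this result.

On these data alone, all four compounds carry a single halogen on one of their rings, so it remains open whether an amine, a carboxylic acid or a nitrile on this ring would also stay within the scatter of compound 4. As far as these compounds go, it also remains open whether any change to the shared core can move the number in this assay beyond the scatter, as each of the four compounds lies within the scatter of the next.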